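Replacing a large group with fluoro in compound 4

The compounds below may be only part of what the source reports. "The series", "measured", "known", "first", "only" and "open" are said of these compounds alone.

Measured in a functional assay on VCaP cells (Homo sapiens) for antiproliferative activity, read by propidium iodide staining, with a stated time of 96 h; on this read-out lower numbers stand for stronger inhibition and higher numbers for weaker inhibition:
Compound 1 `CC(O)(COc1cccc(S(F)(F)(F)(F)F)c1)C(=O)Nc1ccc(C#N)c(C(F)(F)F)c1`: 8000 nM
Compound 2 `CC(O)(COc1cccc(OC(F)(F)F)c1)C(=O)Nc1ccc(S(F)(F)(F)(F)F)cc1`: 18300 nM
Compound 3 `CC(O)(CS(=O)(=O)c1ccc(S(F)(F)(F)(F)F)cc1)C(=O)Nc1cccc(S(F)(F)(F)(F)F)c1`: 17200 nM

Compound 3, at 17200 nM, cannot be told apart from compound 2, at 18300 nM. Compound 1 gives a lower number, 8000 nM, and that gap from compound 3 lies beyond the scatter. Compound 4 `CC(O)(CS(=O)(=O)c1ccc(F)cc1)C(=O)Nc1cccc(S(F)(F)(F)(F)F)c1` departs from compound 3 in one place: one fluorine atom in place of a group of 6 heavy atoms (5 fluorine, 1 sulfur; no ring), on an aromatic carbon. One fluorine atom takes the place of a group of 6 heavy atoms, on an aromatic carbon. Within the data shown here, no measured pair differs in a single place, so the data offer no direct guide to this change. Only a modest effect is anticipated, with no step beyond the scatter in either direction. The estimated outcome is a 1.2-fold higher number from compound 3 to compound 4 (0.07 log units; within the scatter). Compound 4 is expected at 20000 nM, within an estimated range of 8000 nM to 50000 nM.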

Compound 4, half-maximal inhibitory concentration: 37900 nM
For compound 4 the middle estimate is 1.9-fold (0.28 log units) below the measured one; low and high end bracket the measured number.
By their numbers in this assay, from the lowest: compound 1; then compounds 3 and 2 (each within the scatter of the next); then compound 4.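

Among these compounds, the first single-place comparison in this assay comes from setting one fluorine atom in place of the group of 6 heavy atoms (5 fluorine, 1 sulfur) on the aromatic carbon, which gives a 2.2-fold higher number from compound 3 to compound 4 (0.34 log units; beyond the scatter). At this position the larger group therefore goes with the lower number, by a modest step that lies beyond the scatter. Nothing measured here explains this step. The compounds shown leave open how chloro, methyl or methoxy would read on this aromatic carbon. They also leave open whether the same change would give a similar step on another core.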